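This account rests on a few compounds, and the source may have more. Where it says the series, first, only, none or still open, it means among the compounds named here.

For the measured compounds named here, compound 1 `O=c1c2ccccc2ccn1[C@@H]1O[C@H](COP(=O)(O)OP(=O)(O)OP(=O)(O)O)[C@@H](O)[C@H]1O` gives 31 nM in a functional assay for agonist activity at P2Y purinoceptor 2 (Homo sapiens), read by FLIPR (a higher number here means that more compound is needed for the effect, a lower number that less compound is needed), the lowest of the two numbers so far; its nearest neighbour is compound 2 `Cc1cccc2c(=O)n([C@@H]3O[C@H](COP(=O)(O)OP(=O)(O)OP(=O)(O)O)[C@@H](O)[C@H]3O)ccc12`, which gives 557 nM in this assay. Going by the values given here, the one step available, an 18-fold higher number from compound 1 to compound 2 (1.25 log units; beyond the scatter), follows a methyl in place of hydrogen on an aromatic carbon. Compound 3 `Cc1ccc2c(=O)n([C@@H]3O[C@H](COP(=O)(O)OP(=O)(O)OP(=O)(O)O)[C@@H](O)[C@H]3O)ccc2c1` carries the change (methyl in place of hydrogen on an aromatic carbon), a methyl at a different aromatic carbon of the core. With only that large loss as a guide, a loss of some size is expected for compound 3 in this assay, roughly a 3.9-fold higher number from compound 1 to compound 3 (0.59 log units; beyond the scatter). Compound 3 is therefore estimated at 120 nM, in the range 30 nM to 600 nM.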

Compound 3, half-maximal effective concentration: 35 nM
Beside the measured number, compound 3's estimate is 3.4-fold (0.54 log units) above it; the measured number falls inside the stated range.
By their numbers in this assay, from the lowest: compounds 1 and 3 (each within the scatter of the next); then compound 2.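

In this assay, adding a methyl at this position gives a 1.1-fold higher number from compound 1 to compound 3 (0.05 log units; within the scatter), so the position takes the added methyl with no change beyond the scatter. The same replacement at a different aromatic carbon of the core gave an 18-fold higher number from compound 1 to compound 2 (1.25 log units; beyond the scatter), so in these compounds the outcome depends on where the methyl sits. No available evidence bears on this difference between the two positions. On these data alone, whether a longer chain such as ethyl, a methoxy group or an amine would be tolerated at this aromatic carbon as methyl is remains open.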